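From 3-methylphenyl to 3-fluorophenyl

The compounds below may be only part of what the source reports. "The series", "measured", "known", "first", "only" and "open" are said of these compounds alone.

In an ADME assay on microsomes from liver (Canis lupus familiaris) for metabolic stability, read by LC-MS, using NADPH, with a stated time of 10 min, tested at 0.1 uM (a lower number here means slower removal, a higher number faster removal of the compound), compound 1 (`COc1ccc(F)cc1N1C(=O)CSC1c1cccc(C(=O)NCCCCn2cccn2)c1`) gives 480 mL.min-1.g-1 and compound 2 (`Cc1cccc(N2C(=O)CSC2c2cccc(C(=O)NCCCCc3ccccc3)c2)c1`) gives 749 mL.min-1.g-1 as its number, so the two stand within the scatter of each other. Compound 3 (`O=C(NCCCCc1ccccc1)c1cccc(C2SCC(=O)N2c2cccc(F)c2)c1`) has fluoro in place of methyl on an aromatic carbon of compound 2 (fluoro in place of methyl on an aromatic carbon). Among the compounds with values here, no measured pair differs in one place only, so nothing here sizes this change directly. In this assay the expected shift is none beyond the scatter, with no firm direction. The estimated 1.2-fold lower number from compound 2 to compound 3 (0.08 log units; within the scatter) is small. Compound 3 is estimated at 620 mL.min-1.g-1 within an expected range of 300 mL.min-1.g-1 to 1250 mL.min-1.g-1 for now.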

Compound 3, intrinsic clearance in microsomes: 837 mL.min-1.g-1
For compound 3 the middle estimate is 1.4-fold (0.13 log units) below the measured one; measured number inside the range.
By their numbers in this assay, from the lowest: compounds 1, 2 and 3 (each within the scatter of the next).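

Within the data shown here, the exchange of 3-methylphenyl for 3-fluorophenyl gives the first one-place comparison, and in this assay it reads (a 1.1-fold higher number from compound 2 to compound 3 (0.05 log units; within the scatter)). On this ring, meta to a large group, fluoro in place of methyl therefore leaves intrinsic clearance within the scatter. No available evidence bears on this result.

On these data alone, whether an amine or a carboxylic acid at this position would move the number beyond the scatter stays open. Among these compounds, the effect of a longer chain in place of the one in compound 3 is also open.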